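The compounds below may be only part of what the source reports. "The series", "measured", "known", "first", "only" and "open" are said of these compounds alone.

Compound 2 (`Nc1ccccc1NC(=O)CCCCCCc1nc(-c2ccccc2)no1`) gives 23900 nM in a functional assay on A549 cells (Homo sapiens) for antiproliferative activity, read by MTT assay, with a stated time of 72 h (on this read-out higher numbers stand for weaker inhibition and lower numbers for stronger inhibition), as its half-maximal inhibitory concentration. Going by the values given here, the only other measured compound is compound 1 (`COc1ccc(-c2noc(CCCCCCC(=O)NO)n2)cc1`), which gives 13500 nM in this assay as well. Among the compounds with values here, these two numbers lie within the usual scatter of each other, so they cannot be ranked, and compound 2 simply stands level with compound 1 on the numbers so far.

Compound 3 (`Nc1ccccc1NC(=O)CCCCCCc1nc(-c2cccc([N+](=O)[O-])c2)no1`) departs from compound 2 in a single place, with nitro in place of hydrogen on an aromatic carbon, so that phenyl becomes 3-nitrophenyl (nitro in place of hydrogen on an aromatic carbon). Within the data shown here, no measured pair in this small set differs in only one place, so the data give no direct guide to the effect of such a change. From the compounds shown here alone, with nothing to point either way, no step beyond the scatter is expected in this assay and any direction remains open. The expected change is a 1.4-fold lower number from compound 2 to compound 3 (0.15 log units; within the scatter) and no more than that. For compound 3 the estimated value is 17000 nM within an expected range from 6000 nM to 45000 nM in this test.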

Compound 3, half-maximal inhibitory concentration: 20200 nM
The estimate for compound 3 lay 1.2-fold (0.07 log units) below the measured number; measured number inside the range.
By their numbers in this assay, from the lowest: compounds 1, 3 and 2 (each within the scatter of the next).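

In this assay, going by these compounds alone, the swap of phenyl for 3-nitrophenyl gives a 1.2-fold lower number from compound 2 to compound 3 (0.07 log units; within the scatter), and this is the first pair in the set that differs in only one place. It shows that adding a nitro group, with its 3 heavy atoms and 2 hydrogen-bond acceptors, at this aromatic carbon leaves compound 3 level with compound 2 in this test. The position can therefore carry a fairly large group without a step beyond the scatter, although this single pair cannot say how far that holds for other groups. No measurement here bears on why the two compounds stand level.

A single group at a single place leaves open whether an amine or a carboxylic acid on this same aromatic carbon would also stand level with compound 2, and whether a nitro group elsewhere on the phenyl ring would do the same. It also leaves open whether a longer chain in the linker would shift the number beyond the scatter in this assay.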